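The source may hold more compounds than are shown below. What is called first, only, known or untested is meant among the compounds shown, and "the series" means these compounds.

Compound 1 `CCc1nc(NC(CC)CC)c(Cl)nc1-c1ccc(Cl)cc1Cl` gives 71 nM in an assay on IMR-32 cells for displacement of a labelled ligand from corticotropin-releasing factor receptor 1 (Homo sapiens), read by scintillation counting, with a stated time of 2 h (a higher number here means a weaker inhibitor, a lower number a stronger inhibitor), and stands highest of the three numbers recorded. Within the data shown here, compound 2 `CCc1nc(-c2ccc(OC(F)(F)F)cc2OC)c(CC)nc1NC(CC)CC` gives 7.2 nM in this assay, and compound 3 `CCc1nc(-c2ccc(Cl)cc2Cl)c(CC)nc1NC(C1CC1)C1CC1` gives 3.7 nM; both differences from compound 1 lie beyond the scatter, but neither pair isolates a single change, so they carry no step for the present question. Compound 4 `CCc1nc(NC(CC)CC)c(I)nc1-c1ccc(Cl)cc1Cl` differs from compound 1 by iodo in place of chloro on an aromatic carbon. Among the measured compounds shown here, no measured pair shows this halogen exchange, so the expectation rests on compound 1 alone. A step from compound 1 to compound 4 of a 1.4-fold lower number from compound 1 to compound 4 (0.15 log units; within the scatter) is expected, which is essentially none beyond the scatter. Compound 4 is therefore estimated at 50 nM, with a range from 18 nM to 150 nM.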

Compound 4, inhibition constant: 12 nM
Compound 4: the middle estimate sits 4.2-fold (0.62 log units) above what was measured, and the stated range ends above it.
By their numbers in this assay, from the lowest: compounds 3, 2 and 4 (each within the scatter of the next, the first and the last beyond it); then compound 1.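

Among these compounds, this position, on the aromatic carbon next to the ring nitrogen and ortho to the (pentan-3-yl)amino group, gives the first single-place reading: iodo in place of chloro produces a 5.9-fold lower number from compound 1 to compound 4 (0.77 log units; beyond the scatter), a step beyond the scatter. The exchange swaps one heavy atom for another, with no change in hydrogen-bond donors, acceptors or net charge. Nothing available accounts for this step.

Bromo, methyl and nitrile at this carbon remain open. So does whether the step persists with a dicyclopropylmethylamino group in place of the (pentan-3-yl)amino group.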